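Dimethylisoxazole in place of the oxolane side chain

The source may hold more compounds than are shown below. What is called first, only, known or untested is meant among the compounds shown, and "the series" means these compounds.

Compound 3 `Cc1cc(C)c(CN2CCc3c(Cl)cc([C@@H](CO)[C@@H]4CCOC4)c(Cl)c3C2=O)c(=O)[nH]1` gives 1260 nM in an assay for inhibition of histone-lysine N-methyltransferase EZH2 variant Y641N (Homo sapiens), read by scintillation counting, with a stated time of 60 min, in the presence of a further agent that is not named here (a higher number here means a weaker inhibitor, a lower number a stronger inhibitor), the highest of the two plain numbers; its nearest neighbour is compound 2 `Cc1cc(C)c(CN2CCc3c(Cl)cc([C@H](CO)[C@@H]4CCCO4)c(Cl)c3C2=O)c(=O)[nH]1` at 10 nM, reached by a 130-fold higher number from compound 2 to compound 3 (2.10 log units; beyond the scatter). Compound 1 `COC(c1cc(Cl)c2c(c1Cl)C(=O)N(Cc1c(C)cc(C)[nH]c1=O)CC2)C1CCOCC1` stands apart, since in this assay compound 1 gives 310 nM; 0.1 nM (2 entries) across its entries (the several entries of compound 1 in this assay, 310 nM; 0.1 nM (2 entries)). Compound 4 `Cc1cc(C)c(CN2CCc3c(Cl)cc(-c4c(C)noc4C)c(Cl)c3C2=O)c(=O)[nH]1` carries a group of 7 heavy atoms (5 carbon, 1 nitrogen, 1 oxygen; one five-membered aromatic ring with 2 hetero atoms) in place of a group of 8 heavy atoms (6 carbon, 2 oxygen; one five-membered non-aromatic ring with 1 hetero atom), on an aromatic carbon. Among the compounds with values here, no measured step swaps a non-aromatic for an aromatic ring at this carbon, so only the spread of this assay's numbers, from compound 2 through compound 3, frames the expectation. Compound 4 is expected to give 60 nM, within 5 nM to 700 nM. Within the data shown here, that expected step is a 21-fold lower number from compound 3 to compound 4 (1.32 log units; beyond the scatter), towards a lower number, but it rests on no direct analogue.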

Compound 4, inhibition constant: 1.15 nM
Compound 4: middle estimate off by 52-fold (1.72 log units), on the high side; the measured number lies below the stated range.
By their numbers in this assay, from the lowest: compound 4; then compound 2; then compound 3.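

In this assay, 3,5-dimethyl-1,2-oxazol-4-yl on this aromatic carbon gives a 1100-fold lower number from compound 3 to compound 4 (3.04 log units; beyond the scatter) and an 8.7-fold lower number from compound 2 to compound 4 (0.94 log units; beyond the scatter). A low number at this position therefore needs neither a hydrogen-bond donor nor a defined stereocentre in the group, and a five-membered aromatic ring can stand in place of the non-aromatic one. Nothing shown gives a measured reason for either step.

From the compounds shown here alone, whether both methyl groups of the 3,5-dimethyl-1,2-oxazol-4-yl are needed remains open. So does how a phenyl ring or an amine would read on this carbon.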